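Swapping nitro for amino on the benzyl arm of compound 1

A few compounds are considered here, and "the series" means these few. Any claim that something is new, unique, unknown or untested is made for them only; others in the source may bear on it.

Compound 1 `COc1ccc(CN(C(=O)CSc2nc3ccccc3s2)c2cc(OC)c(OC)c(OC)c2)cc1[N+](=O)[O-]` gives 682 nM in a functional assay on MGC-803 cells (Homo sapiens) for antiproliferative activity, read by MTT assay, with a stated time of 48 h; on this read-out lower numbers stand for stronger inhibition and higher numbers for weaker inhibition. Compound 2 `COc1ccc2nc(SCC(=O)N(Cc3ccc(OC)c(O)c3)c3cc(OC)c(OC)c(OC)c3)sc2c1` gives 71 nM. Compound 3 `COc1ccc(CN(C(=O)CSc2nc3c(C)cccc3s2)c2cc(OC)c(OC)c(OC)c2)cc1O` gives 493 nM.

Among these three, compound 1 has the highest number; compound 3 lies within the scatter of it, while compound 2 lies well below it. Among the measured compounds shown here, the one single-point step in the set, a 6.9-fold higher number from compound 2 to compound 3 (0.84 log units; beyond the scatter), concerns the group on the sulfur, not the benzyl arm, so it does not bear on the change considered here.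

Compound 4 `COc1ccc(CN(C(=O)CSc2nc3ccccc3s2)c2cc(OC)c(OC)c(OC)c2)cc1N` differs from compound 1 in one place: amino in place of nitro on an aromatic carbon. For the measured compounds named here, no measured pair isolates this exchange. Going by the values given here, the only guide is that compound 3, which carries a hydrogen-bond donor at the same place on the benzyl arm but also a different group on the sulfur, gives 493 nM, within the scatter of compound 1. Compound 4 is therefore expected to show a 1.5-fold lower number from compound 1 to compound 4 (0.18 log units; within the scatter), with no step beyond the scatter in either direction. The estimate for compound 4 is 450 nM, in the range 150 nM to 1400 nM.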

Compound 4, half-maximal inhibitory concentration: 84 nM
For compound 4 the middle estimate is 5.4-fold (0.73 log units) above the measured one; the measured number lies below the stated range.
By their numbers in this assay, from the lowest: compounds 2 and 4 (each within the scatter of the next); then compounds 3 and 1 (each within the scatter of the next).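

In this assay, amino in place of nitro on the aromatic carbon ortho to a methoxy group gives an 8.1-fold lower number from compound 1 to compound 4 (0.91 log units; beyond the scatter), and this is the first pair shown that isolates a change on the benzyl arm. The number therefore depends on which group stands at this place, something the earlier single step could not show, as it concerned only the group on the sulfur. No measurement shown here accounts for the size of this step.

From the compounds shown here alone, it remains open whether a methylamino, dimethylamino or acetamido group at this place on the core of compound 4 would give a similar number. Also open, going by these compounds, is whether the same exchange would give a step of this size with a methoxy or methyl group on the benzothiazole attached to the sulfur.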